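Swapping the oxirane arm for isopropyl in a fumagillol-like core

The source may hold more compounds than are shown below. What is called first, only, known or untested is meant among the compounds shown, and "the series" means these compounds.

Measured compounds:
compound 1, `CO[C@@H]1C(=O)CO[C@]2(COC(C)(C)O2)[C@@]1(O)C1(C)CO1` — 119000 nM
compound 2, `CO[C@@H]1[C@H](OC(=O)NC(=O)CCl)CO[C@]2(COC(C)(C)O2)[C@@]1(OC(=O)NC(=O)CCl)C1OC1CCCc1ccccc1` — 16000 nM
compound 3, `CO[C@@H]1[C@H](OC(=O)NC(=O)CCl)CO[C@]2(COC(C)(C)O2)[C@@]1(O)C1OC1CCCc1ccccc1` — 68000 nM; 90000 nM (2 entries)

In a functional assay on cells (Endothelial cell, Sus scrofa) for antiproliferative activity (a higher number here means a weaker inhibitor, a lower number a stronger inhibitor), compound 2 gives 16000 nM, the lowest of the two single numbers; the nearest neighbour on that scale is compound 1, which gives 119000 nM, a gap beyond the scatter. Compound 3 stands apart, since its several entries do not settle on one number (the several entries of compound 3 in this assay, 68000 nM; 90000 nM (2 entries)). No step between two measured compounds is shown, so no cause for the gap between compound 1 and compound 2 is offered here.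

The move from compound 2 to compound 4, `CO[C@@H]1[C@H](OC(=O)NC(=O)CCl)CO[C@]2(COC(C)(C)O2)[C@@]1(OC(=O)NC(=O)CCl)C(C)C`, is isopropyl in place of 3-(3-phenylpropyl)oxiran-2-yl on a saturated ring carbon. This removes the only hydrogen-bond acceptor that was counted in the leaving group, while the two (((chloromethyl)carbonyl)carbamoyl)oxy groups stay.

Since the weaker compounds 1 and 3 both carry the oxirane and still sit far above compound 2, a step toward weaker inhibition beyond the scatter is expected in this assay for compound 4, as a 3.1-fold higher number from compound 2 to compound 4 (0.49 log units; beyond the scatter). Compound 4 is therefore estimated at 50000 nM, with a plausible range from 15000 nM to 200000 nM.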

Compound 4, half-maximal inhibitory concentration: 23000 nM
For compound 4 the middle estimate is 2.2-fold (0.34 log units) above the measured one, within the range that was stated.
By their numbers in this assay, from the lowest: compounds 2 and 4 (each within the scatter of the next); then compound 1.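

In this assay, replacing the 3-(3-phenylpropyl)oxiran-2-yl arm with isopropyl on this saturated ring carbon gives a 1.4-fold higher number from compound 2 to compound 4 (0.16 log units; within the scatter). This single pair therefore shows that the oxirane and the phenyl ring of this arm can both leave this position with no change beyond the scatter, so long as both (((chloromethyl)carbonyl)carbamoyl)oxy groups stay in place. Nothing measured here offers a reason why so large an exchange leaves the reading within the scatter.

From the compounds shown here alone, it remains open whether the same holds for other groups on this ring carbon, such as a primary amine, a carboxylic acid or a longer alkyl chain. Going by these compounds, it is also open whether isopropyl would behave the same way with a free hydroxyl in place of either (((chloromethyl)carbonyl)carbamoyl)oxy group.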